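Removing the amino group from compound 1

The compounds below may be only part of what the source reports. "The series", "measured", "known", "first", "only" and "open" are said of these compounds alone.

Among the compounds with values here, in an ADME assay on MRC5 cells (Homo sapiens) for cytotoxicity, read by fluorescence, with a stated time of 24 h (a higher number here means a weaker inhibitor, a lower number a stronger inhibitor), compound 1 (`Nc1ccccc1C(=O)N/N=C/c1ccc2no[n+]([O-])c2c1`) gives 122000 nM, the highest number of the three measured so far. Compound 2 (`N#Cc1c(-c2ccco2)[n+]([O-])c2ccc(C3OCCO3)cc2[n+]1[O-]`) gives 35700 nM and compound 3 (`COc1ccc(-c2c(C#N)[n+]([O-])c3cc(C4OCCO4)ccc3[n+]2[O-])cc1`) gives 15000 nM. Both numbers lie lower than that of compound 1 by more than the scatter.

Compound 4 (`O=C(N/N=C/c1ccc2no[n+]([O-])c2c1)c1ccccc1`) is still unmeasured. Its difference from compound 1 is hydrogen in place of amino on an aromatic carbon, so that 2-aminophenyl becomes phenyl.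

Within the data shown here, no measured pair removes an amino group. Among the measured compounds shown here, the only measured step is a 2.4-fold lower number from compound 2 to compound 3 (0.38 log units; beyond the scatter). That step exchanges a different group on a different core, so it bears on this change only loosely, as a guide to the size a single exchange can reach in this small set. No step beyond the scatter is therefore expected in this assay. A slight lean towards a lower number rests only on compound 1 standing at the top of the measured range at 122000 nM. The estimated step is a 1.3-fold lower number from compound 1 to compound 4 (0.11 log units; within the scatter). For compound 4 the expected value is 95000 nM, with an estimated range of 40000 nM to 200000 nM.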

Compound 4, half-maximal inhibitory concentration: 130000 nM
Compound 4: middle estimate off by 1.4-fold (0.14 log units), on the low side, within the range that was stated.
By their numbers in this assay, from the lowest: compound 3; then compound 2; then compounds 1 and 4 (each within the scatter of the next).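

In this assay the change from 2-aminophenyl to phenyl gives a 1.1-fold higher number from compound 1 to compound 4 (0.03 log units; within the scatter), so on this aromatic carbon, ortho to a large group, the amino group can give way to hydrogen with no step beyond the scatter. Within the data shown here, this is the first measured step at this position and on the core of compound 1, whereas a 2.4-fold lower number from compound 2 to compound 3 (0.38 log units; beyond the scatter) exchanged a different group on a different core and could only loosely suggest the size of a single exchange. No measurement available here accounts for this result, and it gives no information on what the amino group contributes in these cells.

The compounds shown leave open whether a hydroxyl group, a dimethylamino group or a carboxylic acid in the same place would also stay within the scatter of compound 1, or would move the number away from it. Also open, on these data alone, is whether the match between compound 1 and compound 4 holds in other cell lines or at other exposure times, since this single pair comes from one cytotoxicity read-out only.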